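From chloro to methoxy: an expected small step

This account rests on a few compounds, and the source may have more. Where it says the series, first, only, none or still open, it means among the compounds named here.

Values in a functional assay on A549 cells (Homo sapiens) for inhibition, read by MTT assay, with a stated time of 24 h (a higher number here means a weaker inhibitor, a lower number a stronger inhibitor), so far:
compound 1 `CC1(C)[C@H]2CC[C@]1(C)N(Cc1cn(-c3ccccc3C#N)nn1)C(=O)C2` gives 100 nM
compound 2 `CC1(C)[C@H]2CC[C@]1(C)N(Cc1cn(-c3ccc(O)cc3)nn1)C(=O)C2` gives 140 nM
compound 3 `CC1(C)[C@H]2CC[C@]1(C)N(Cc1cn(-c3ccc(Cl)cc3)nn1)C(=O)C2` gives 70 nM

Compound 3 stands close to both others. The gaps to it are a 1.4-fold lower number from compound 1 to compound 3 (0.15 log units; within the scatter) and a 2.0-fold lower number from compound 2 to compound 3 (0.30 log units; within the scatter) so no order among the three can be claimed. The remaining gap reads a 1.4-fold higher number from compound 1 to compound 2 (0.15 log units; within the scatter) and is small as well.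

Compound 4 `COc1ccc(-n2cc(CN3C(=O)C[C@@H]4CC[C@@]3(C)C4(C)C)nn2)cc1` differs from compound 3 by methoxy in place of chloro on an aromatic carbon and so has methoxy in place of chloro on an aromatic carbon. Going by the values given here, no measured compound carries methoxy. The nearest evidence comes from compound 2 where a 2.0-fold lower number from compound 2 to compound 3 (0.30 log units; within the scatter) accompanied chloro in place of hydroxy on an aromatic carbon. No step beyond the scatter is therefore expected in this assay in either direction. The expected step is a 1.4-fold higher number from compound 3 to compound 4 (0.15 log units; within the scatter) as estimated here. For compound 4 the estimated value is 100 nM with an expected range from 50 nM to 200 nM in this series.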

Compound 4, half-maximal inhibitory concentration: 50 nM
Compound 4: the middle estimate sits 2.0-fold (0.30 log units) above what was measured; the measured number falls inside the stated range.
By their numbers in this assay, from the lowest: compounds 4, 3, 1 and 2 (each within the scatter of the next, the first and the last beyond it).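

In this assay, methoxy on the aromatic carbon para to a large group keeps the number within the scatter of both chloro (with a 1.4-fold lower number from compound 3 to compound 4 (0.15 log units; within the scatter)) and 2-cyanophenyl (with a 2.0-fold lower number from compound 1 to compound 4 (0.30 log units; within the scatter)), so this position accepts the 4-methoxyphenyl group as readily as those two aryl groups. Going by these compounds alone, what is new is the methyl in place of hydrogen on the oxygen (with a 2.8-fold lower number from compound 2 to compound 4 (0.45 log units; beyond the scatter)), the first step beyond the scatter, though a modest one resting on this single pair. Nothing available gives a reason for this step.

On these data alone, whether an amine, a carboxylic acid or a longer chain on the oxygen, such as ethoxy, would hold the number in this range stays open. Also open, as far as these compounds go, is whether these steps would carry over to a changed core.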